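The source may hold more compounds than are shown below. What is called first, only, known or untested is meant among the compounds shown, and "the series" means these compounds.

Three compounds have so far been measured in an assay on HEK293 cells for displacement of a labelled ligand from adenosine receptor A2b (Homo sapiens), read by scintillation counting, with a stated time of 30 min, tested at 10 uM; on this read-out lower numbers stand for less inhibition and higher numbers for more inhibition at the one concentration tested (going by the name of the read-out):

compound 1, `COc1cccc2cc(C(=O)N[C@@H](CO)C(=O)O)c(=O)oc12`, gives 24%
compound 2, `COCCNC(=O)c1cc2cccc(OC)c2oc1=O`, gives 18%
compound 3, `COc1cccc2cc(C(=O)Nc3c(C#N)ncn3-c3ccccc3)c(=N)oc12`, gives 9%

All three share one core and differ in the group carried on the amide-type nitrogen. Compound 3 stands lowest of the three numbers in this assay. Its nearest neighbour is compound 2, whose number lies within the scatter of that of compound 3, so no order between these two can be claimed. Compound 1 lies further off, beyond the scatter, so compound 1 shows more inhibition than compound 3.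

Compound 4, `COc1ccc(-n2cnc(C#N)c2NC(=O)c2cc3cccc(OC)c3oc2=N)cc1`, has not yet been measured. It differs from compound 3 in one place: methoxy in place of hydrogen on an aromatic carbon. Cut one bond further out, the change reads phenyl to 4-methoxyphenyl.

Among the compounds with values here, the only measured step, a number 6 percentage points lower from compound 1 to compound 2 (within the scatter), concerns a change on the amide-type nitrogen and does not touch this phenyl, so no measured step bears directly on the change from compound 3 to compound 4. Within the data shown here, the one step seen so far stayed within the scatter, and no guide exists for this place. The expectation is therefore no step beyond the scatter, that is a number 1 percentage points higher from compound 3 to compound 4 (within the scatter). Compound 4 is estimated at 10% in this assay, with a range from 0% to 25%.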

Compound 4, a percentage reported as inhibition, at one concentration (the size of the read-out at that concentration, not a potency): 5%
For compound 4 the middle estimate is 5 percentage points above the measured one; low and high end bracket the measured number.
By their numbers in this assay, from the lowest: compounds 4, 3, 2 and 1 (each within the scatter of the next, the first and the last beyond it).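

In this assay, the change from phenyl to 4-methoxyphenyl gives a number 4 percentage points lower from compound 3 to compound 4 (within the scatter). Within the data shown here, this is the first view of the ring on the far side of the amide-type nitrogen, since the earlier step between compounds changed only the group on that nitrogen itself; here a methoxy on an aromatic carbon, para to a large group, leaves compound 3 and compound 4 with no order that can be claimed between them, and a single pair shows only that this one substitution produces no step beyond the scatter. Nothing available on these compounds offers an explanation for this result.

Whether a different group at this same place, such as an amine, a carboxylic acid or a longer chain like butoxy, would move the number beyond the scatter remains open, since methoxy is the only group shown there apart from hydrogen. From the compounds shown here alone, the read-out also gives only the size of the inhibition at one concentration, so the potency of compound 3 and compound 4 stays unknown.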